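The source may report more compounds than this note shows. Statements on the series, on what has been measured and on what is new or still open speak of the compounds shown alone.

Measured compounds:
Compound 1, `CCCCCCCCC(=O)N1c2ccccc2CCC1C(=O)Nc1ccccc1C(F)(F)F`, gives 3350 nM in a functional assay on MDA-MB-231 cells (Homo sapiens) for cytotoxicity, read by sulforhodamine B assay, with a stated time of 72 h; a higher number here means a weaker inhibitor of growth, a lower number a stronger inhibitor of growth.
Compound 2, `CCCCCCCCC(=O)N1c2ccccc2CCC1C(=O)Nc1ccccc1O`, gives 54300 nM in this assay.
Compound 3, `O=C(Nc1cc(C(F)(F)F)cc(C(F)(F)F)c1)C1CCc2ccccc2N1C(=O)c1ccccc1`, gives 2430 nM in this assay.

Compound 1 stands second highest of the three numbers; compound 3 is nearest, within the scatter, and compound 2 furthest, beyond it. Within the data shown here, the only single-point step measured is a 16-fold higher number from compound 1 to compound 2 (1.21 log units; beyond the scatter), which concerns a different part of the molecule from the change considered here. Compound 4, `O=C(Nc1ccccc1C(F)(F)F)C1CCc2ccccc2N1C(=O)c1ccccc1Cl`, differs from compound 1 by 2-chlorophenyl in place of octyl on a carbonyl carbon. Among the measured compounds shown here, no measured pair isolates this change; compound 3 carries a phenyl on that same carbonyl, though with a different anilide, and its value lies within the scatter of compound 1. For compound 4 a step of a 1.1-fold lower number from compound 1 to compound 4 (0.05 log units; within the scatter) is therefore expected, nothing beyond the scatter. Compound 4 is estimated at 3000 nM, range 1200 nM to 8000 nM.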

Compound 4, concentration for 50% growth inhibition: 2530 nM
Beside the measured number, compound 4's estimate is 1.2-fold (0.07 log units) above it; the range from low to high includes it.
By their numbers in this assay, from the lowest: compounds 3, 4 and 1 (each within the scatter of the next); then compound 2.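

Among these compounds, on the carbonyl carbon bound to the amide-type nitrogen in a ring, the first direct pair in this assay shows that 2-chlorophenyl can replace octyl without a change beyond the scatter (a 1.3-fold lower number from compound 1 to compound 4 (0.12 log units; within the scatter)). With the anilide of compound 1 held constant, an aromatic ring and an open chain therefore read alike at this position. No evidence available here explains this.

Open questions are whether an amine, a carboxylic acid or a longer chain on this carbonyl would leave the number unchanged. Also open, as far as these compounds go, is whether the chlorine matters, compared with an unsubstituted phenyl on the same anilide.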